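This account rests on a few compounds, and the source may have more. Where it says the series, first, only, none or still open, it means among the compounds named here.

Measured compounds:
Compound 1 `Cc1ccc2[nH]c(=O)c(CN(Cc3ccc(OC(C)C)cc3)Cc3ccc(C(C)(C)C)cc3)cc2c1` gives > 5000 nM in a toxicity assay on MDCK cells (Canis lupus familiaris) for cytotoxicity, read by crystal violet staining, with a stated time of 48 h (on this read-out higher numbers stand for lower toxicity in this test and lower numbers for higher toxicity in this test), which is a limit of the assay rather than a number.
Compound 2 `Cc1ccc2[nH]c(=O)c(CN(Cc3ccc(C(C)(C)C)cc3)Cc3ccc(N(C)C)c(Cl)c3)cc2c1` gives > 10000 nM in this assay, likewise a limit and not a number.

Compound 2 therefore stands at a limit of this assay, and the other value shown is a limit as well, so neither compound has a true half-maximal cytotoxic concentration to compare. For the measured compounds named here, the only measured step, a step that the two limits leave unreadable from compound 1 to compound 2, cannot be sized because the limit of > 10000 nM in this assay, at which 1 of the 2 values shown sits, and the limit of > 5000 nM in this assay, at which 1 of the 2 values shown sits, bound both values.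

Compound 3 `Cc1ccc2[nH]c(=O)c(CN(Cc3ccc(C(C)(C)C)cc3)C(C)c3ccc(N(C)C)c(Cl)c3)cc2c1` differs from compound 2 by methyl in place of hydrogen on a saturated chain carbon bound to an amine nitrogen and an aromatic carbon. Going by the values given here, no measured step bears directly on this change; the one step available, 3-chloro-4-(dimethylamino)phenyl in place of 4-isopropoxyphenyl, is itself unreadable. What the data do show is that both measured compounds sit at limits of low toxicity in this assay, and a single methyl added on the saturated chain carbon is a small change in this series. The step from compound 2 to compound 3 is therefore expected to be none beyond the scatter, estimated as a step that the limit leaves unreadable from compound 2 to compound 3. Compound 3 is estimated at 12000 nM, with a range from 4000 nM to 40000 nM, most likely reported again only as a limit.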

Compound 3, half-maximal cytotoxic concentration: 9800 nM
Beside the measured number, compound 3's estimate is 1.2-fold (0.09 log units) above it; low and high end bracket the measured number.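

In this assay, for the compounds shown here, compound 3 gives 9800 nM, the first true number in this set, so with a methyl at this position the half-maximal cytotoxic concentration can be read and not only bounded. For methyl in place of hydrogen on a saturated chain carbon bound to an amine nitrogen and an aromatic carbon, the data give an at least 1.0-fold lower number from compound 2 to compound 3 (0.00 log units; that floor lies within the scatter); this is only a floor, so a larger change remains possible, but none beyond the scatter is shown. The step that links compound 3 to compound 1 cannot be read because the value on that side is a limit: the limit of > 5000 nM in this assay, at which 1 of the 3 values shown sits.

From the compounds shown here alone, the true size of the methyl step stays open, and so does whether an ethyl or a cyclopropyl on the same saturated chain carbon would move the number at all. Also open, going by these compounds, is whether the methyl would behave in the same way with 4-isopropoxyphenyl in place of 3-chloro-4-(dimethylamino)phenyl, and whether any of this carries over to a read-out other than this assay.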